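Taking one methoxy off the trimethoxyphenyl group

This account rests on a few compounds, and the source may have more. Where it says the series, first, only, none or still open, it means among the compounds named here.

In a functional assay on PC-3 cells (Homo sapiens) for antiproliferative activity, read by MTT assay, with a stated time of 48 h (on this read-out higher numbers stand for weaker inhibition and lower numbers for stronger inhibition), compound 1 (`COc1ccc(CN(C(=O)CSc2nc3ccccc3s2)c2cc(OC)c(OC)c(OC)c2)cc1`) gives 8460 nM and compound 2 (`COc1ccc(CN(C(=O)CSc2nc3ccccc3s2)c2cc(OC)c(OC)c(OC)c2)cc1[N+](=O)[O-]`) gives 26500 nM. Compound 3 (`COc1cc(CN(C(=O)CSc2nc3ccccc3s2)c2cc(OC)c(OC)c(OC)c2)cc(OC)c1OC`) reports only a limit, > 80000 nM, and not a number; this is the limit of > 80000 nM in this assay, at which 1 of the 3 values shown sits.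

Compound 4 (`COc1ccc(CN(C(=O)CSc2nc3ccccc3s2)c2cc(OC)c(OC)c(OC)c2)cc1OC`) departs from compound 3 by one change, hydrogen in place of methoxy on an aromatic carbon, turning 3,4,5-trimethoxyphenyl into 3,4-dimethoxyphenyl.

The closest evidence is the opposite kind of change, to 3,4,5-trimethoxyphenyl, which gave an at least 9.4-fold higher number from compound 1 to compound 3 (0.97 log units; beyond the scatter) and also an at least 3.0-fold higher number from compound 2 to compound 3 (0.47 log units; beyond the scatter). Adding a nitro group to the ring of compound 1 likewise gave a 3.1-fold higher number from compound 1 to compound 2 (0.50 log units; beyond the scatter). The 3,4-dimethoxyphenyl group is a halfway case between the groups of compound 1 and compound 3, so a modest move to a lower number is expected, probably not all the way back to compound 1. The expected change is an at least 3.6-fold lower number from compound 3 to compound 4 (0.56 log units; beyond the scatter). For compound 4 the estimate is 22000 nM, with an expected range of 7000 nM to 70000 nM.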

Compound 4, half-maximal inhibitory concentration: > 80000 nM
Compound 4: no number, only a limit; the forecaster's own chance of this, stated with the estimate: 15%; middle value at least 3.6-fold (0.56 log units) away from the limit.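

Taking one methoxy off the 3,4,5-trimethoxyphenyl group does not bring the compound back into the measurable range in this assay: compound 4 also gives only a limit, so its step from compound 3 cannot be read. The third methoxy is therefore not needed for the loss, since the 3,4-dimethoxyphenyl group alone already gives an at least 9.4-fold higher number from compound 1 to compound 4 (0.97 log units; beyond the scatter), while methoxy in place of nitro on the same ring carbon gives an at least 3.0-fold higher number from compound 2 to compound 4 (0.47 log units; beyond the scatter). Any difference between compound 3 and compound 4 stays hidden, as both stand at the same ceiling: the limit of > 80000 nM in this assay, at which 2 of the 4 values shown sit.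

As far as these compounds go, it remains open how far compound 3 and compound 4 lie beyond that limit. From the compounds shown here alone, it is also open whether a hydroxy group, an amine or a fluorine atom on that ring carbon would keep the number close to that of compound 1.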